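Lengthening a Side Chain on a Shared Core

The source may hold more compounds than are shown below. What is called first, only, known or untested is meant among the compounds shown, and "the series" means these compounds.

Compound 1 `Cc1ccc(-c2cc(Cl)cc(C(=O)Nc3nn[nH]n3)n2)cc1` gives 86% in a functional assay on the whole organism with Rattus norvegicus as the target, at a dose of 1 mg/kg by the oral route; a higher number here means a stronger effect of the compound at the dose given, a lower number a weaker effect. Compound 2 `CCc1ccc(-c2cc(Cl)cc(C(=O)Nc3nn[nH]n3)n2)cc1` gives 49% in this assay. Within the data shown here, the one change between them is methyl in place of hydrogen on a saturated chain carbon bound to an aromatic carbon, and this step a number 37 percentage points lower from compound 1 to compound 2 (beyond the scatter).

Compound 3 `CCOc1cc(C(=O)Nc2nn[nH]n2)nc(-c2ccc(N)cc2)c1` gives 52% in this assay; how its core differs from that of compound 1 is not broken down here. Compound 4 `CCCOc1cc(C(=O)Nc2nn[nH]n2)nc(-c2ccc(N)cc2)c1` has not yet been measured. It differs from compound 3 by methyl in place of hydrogen on a saturated chain carbon, two bonds along the chain from an oxygen on an aromatic ring. This is the same kind of change as from compound 1 to compound 2, not the same: there the new methyl sat on a saturated chain carbon bound to an aromatic carbon, here it sits on a saturated chain carbon, two bonds along the chain from an oxygen on an aromatic ring.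

Among the measured compounds shown here, only one earlier example of this kind of change is known, and it made a large step downward. For compound 4 a step of a number 22 percentage points lower from compound 3 to compound 4 (beyond the scatter) is therefore expected, smaller than before because compound 3 starts from only 52%. Compound 4 is estimated to give 30%, between 5% and 60%.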

Compound 4, a percentage reported as inhibition, in the whole organism at one dose (the size of the read-out at that dose, not a potency): 64%
Compound 4: middle estimate off by 34 percentage points, on the low side, outside the stated range (above it).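

Going from ethoxy to propoxy gives a number 12 percentage points higher from compound 3 to compound 4 (beyond the scatter) in this assay, so the added methyl moves the read-out the opposite way from the earlier case on the other core: the same change on two cores in this assay, a number 37 percentage points lower (beyond the scatter) from compound 1 to compound 2 and a number 12 percentage points higher (beyond the scatter) from compound 3 to compound 4, 49 percentage points apart, beyond the scatter of two such steps. This shows that, in these two examples, the direction of the change on one core does not predict its direction on the other, so one step is a poor guide to the next. It does not show why the two steps differ, since they differ in both core and place, one on a saturated chain carbon bound to an aromatic carbon and the other two bonds along the chain from an oxygen on an aromatic ring, and two steps cannot separate those factors.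

The compounds shown leave open whether a still longer chain, such as butoxy, on the core of compound 3 would continue the rise or reverse it. They also leave open how a propyl group in place of the ethyl of compound 2 would read out on that core.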